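The source may hold more compounds than are shown below. What is called first, only, known or untested is meant among the compounds shown, and "the series" means these compounds.

Compound 1 `CC(C)=CCC[C@]1(C)/C=C/[C@@H](OC(=O)C=C(C)C)[C@](C)(O)/C=C/C(=O)/C(CN(C)C)=C\C1`: 590 nM
Compound 2 `CC(C)=CCC[C@]1(C)/C=C/[C@@H](OC(=O)C=C(C)C)[C@](C)(O)/C=C/C(=O)/C(CN2CCCC2)=C\C1`: 180 nM
Compound 3 `CC[Si](CC)(CC)C/C1=C/C[C@](C)(CCC=C(C)C)/C=C/[C@@H](OC(=O)C=C(C)C)[C@](C)(O)/C=C/C1=O`: 3100 nM

These values come from a functional assay on A549 cells (Homo sapiens) for antiproliferative activity, read by MTT assay, with a stated time of 48 h; on this read-out lower numbers stand for stronger inhibition and higher numbers for weaker inhibition. Compound 3 has the highest number of the three, so it is the weakest inhibitor measured so far. Compound 4 `CO/N=C/C1=C/C[C@](C)(CCC=C(C)C)/C=C/[C@@H](OC(=O)C=C(C)C)[C@](C)(O)/C=C/C1=O` has not yet been measured. It differs from compound 3 at one place, on a double-bonded ring carbon: a group of 4 heavy atoms (2 carbon, 1 nitrogen, 1 oxygen; no ring) in place of a group of 8 heavy atoms (7 carbon, 1 silicon; no ring), on a double-bonded ring carbon. The silicon goes with the group that leaves.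

Going by the values given here, no measured step makes this exact change, so the evidence is indirect. Two steps put the silicon-bearing group in place of a nitrogen-bearing one: a 5.3-fold higher number from compound 1 to compound 3 (0.72 log units; beyond the scatter), which is modest, and a 17-fold higher number from compound 2 to compound 3 (1.24 log units; beyond the scatter), which is large. A third step, a 3.3-fold lower number from compound 1 to compound 2 (0.52 log units; beyond the scatter), shows that the number also moves, modestly, when one nitrogen-bearing group replaces another. Compound 4 loses the silicon group and carries nitrogen, but in a different kind of group that neither compound 1 nor compound 2 contains. A modest move to a lower number therefore seems likely, though with wide uncertainty.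

The expected change is a 2.4-fold lower number from compound 3 to compound 4 (0.38 log units; beyond the scatter). The estimated value for compound 4 is 1300 nM, with an expected range of 350 nM to 4500 nM.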

Compound 4, half-maximal inhibitory concentration: 3470 nM
Compound 4: middle estimate off by 2.7-fold (0.43 log units), on the low side, and the stated range covers the measured number.
By their numbers in this assay, from the lowest: compound 2; then compound 1; then compounds 3 and 4 (each within the scatter of the next).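

In this assay the silicon-bearing group and the group of nitrogen and oxygen cannot be told apart on this double-bonded ring carbon: the exchange gives a 1.1-fold higher number from compound 3 to compound 4 (0.05 log units; within the scatter) and so shows that removing the silicon alone brings no gain. The position still responds to what it carries, as compound 4 compares poorly with the two compounds that have an amine on a saturated chain carbon, giving a 5.9-fold higher number from compound 1 to compound 4 (0.77 log units; beyond the scatter) and a 19-fold higher number from compound 2 to compound 4 (1.29 log units; beyond the scatter) so that a nitrogen in the group is not enough by itself to reach their lower numbers. No measurement shown here explains these differences.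

The compounds shown contain only two amines at this position, dimethylamino and pyrrolidin-1-yl, so it remains open whether a piperidine, a morpholine or a primary amine on the same saturated chain carbon would give a lower number still. Also open is what a plain alkyl chain or a carboxylic acid would do here, since neither appears among these compounds to show how much of the result depends on the amine.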